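A few compounds are considered here, and "the series" means these few. Any claim that something is new, unique, unknown or untested is made for them only; others in the source may bear on it.

In a functional assay on MCF7 cells (Homo sapiens) for cytotoxicity, read by MTT assay, with a stated time of 48 h (on this read-out higher numbers stand for weaker inhibition and lower numbers for stronger inhibition), compound 1 `OC[C@@H]1C[C@H](CO)[C@@H]2C(c3ccc(Br)cc3)=NO[C@H]12` reads > 50 ug/mL, which is a limit of the assay and not a number. Among the measured compounds shown here, compound 2 `COc1ccc(C2=NO[C@@H]3[C@H](CO)C[C@H](CO)[C@H]23)cc1` gives 23.7 ug/mL, the only true number so far. Compound 3 `OC[C@@H]1C[C@H](CO)[C@@H]2C(c3ccc(F)cc3)=NO[C@H]12` carries fluoro in place of methoxy on an aromatic carbon. For the measured compounds named here, one measured step bears on this change, methoxy in place of bromo on an aromatic carbon, and it is an at least 2.1-fold lower number from compound 1 to compound 2 (0.32 log units; beyond the scatter). As far as these compounds go, that step is beyond the scatter but rests on (the limit of > 50 ug/mL in this assay, at which 1 of the 2 values shown sits), so its true size remains open. Losing the methoxy may therefore give back some inhibition, though no shift beyond the scatter is firmly expected. The estimated step is a 1.5-fold higher number from compound 2 to compound 3 (0.17 log units; within the scatter), slightly toward weaker inhibition. For compound 3 the expected value is 35 ug/mL, with an estimated range from 16 ug/mL to 70 ug/mL.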

Compound 3, half-maximal inhibitory concentration: > 50 ug/mL
Compound 3: only a limit was reported; the forecaster's own chance of this, stated with the estimate: 35%; at least 1.4-fold (0.15 log units) between middle value and limit.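

With fluoro in place of methoxy on an aromatic carbon para to a large group, this assay shows an at least 2.1-fold higher number from compound 2 to compound 3 (0.32 log units; beyond the scatter). Compound 3 gives > 50 ug/mL, which is a limit of the assay and not a number. Methoxy therefore stands alone among the three groups shown at this position, as fluoro and bromo both fail to give a true number, and the small fluoro does not recover what the bromo lacks.

As far as these compounds go, the step between compound 1 and compound 3 cannot be read, and how far either lies from compound 2 stays open, because of where the values fall: the limit of > 50 ug/mL in this assay, at which 2 of the 3 values shown sit. From the compounds shown here alone, whether the effect is particular to methoxy, or would also appear with an ethoxy, a hydroxyl or an amine at this place, remains open.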